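Urea and thiourea benzyloxybenzamides: the step to compound 4

This account rests on a few compounds, and the source may have more. Where it says the series, first, only, none or still open, it means among the compounds named here.

The series shares one core and varies the benzyl ring on the ether oxygen and the urea or thiourea link. In a functional assay on HT-29 cells (Homo sapiens) for inhibition, read by MTT assay, with a stated time of 48 h (a higher number here means a weaker inhibitor, a lower number a stronger inhibitor), compound 1 `Cc1ccc(NC(=S)NC(=O)c2ccc(OCc3cccc(Cl)c3)cc2)cc1-c1nc2ccccc2[nH]1` gives 35300 nM, and compound 2 `Cc1ccc(NC(=S)NC(=O)c2ccc(OCc3cccc(F)c3)cc2)cc1-c1nc2ccccc2[nH]1` gives 55300 nM. Compound 3 `Cc1ccc(NC(=O)NC(=O)c2ccc(OCc3ccc(C(F)(F)F)cc3)cc2)cc1-c1nc2ccccc2[nH]1`, a urea rather than a thiourea, gives 7830 nM in this assay, the lowest of the three numbers; the gap to compound 1 is beyond the scatter, as is the larger gap to compound 2.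

Compound 4 `Cc1ccc(NC(=O)NC(=O)c2ccc(OCc3ccccc3Cl)cc2)cc1-c1nc2ccccc2[nH]1` differs from compound 3 in one place: 2-chlorophenyl in place of 4-(trifluoromethyl)phenyl on a saturated chain carbon bound to an oxygen on an aromatic ring. Among the measured compounds shown here, the only measured single step, a 1.6-fold higher number from compound 1 to compound 2 (0.19 log units; within the scatter), exchanges one halogen for another on the benzyl ring and stays within the scatter, but it runs between thioureas and does not touch a trifluoromethyl group, so it bears on the present change only loosely. For the measured compounds named here, no measured pair isolates the trifluoromethyl-to-chloro exchange or the shift of the substituent on that ring. The expectation for compound 4 is therefore a modest step in this assay, a 1.5-fold higher number from compound 3 to compound 4 (0.19 log units; within the scatter), towards a higher number, with wide uncertainty. Compound 4 is estimated at 12000 nM, with a range from 3500 nM to 45000 nM.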

Compound 4, half-maximal inhibitory concentration: 9010 nM
Compound 4: middle estimate off by 1.3-fold (0.12 log units), on the high side; the range from low to high includes it.
By their numbers in this assay, from the lowest: compounds 3 and 4 (each within the scatter of the next); then compounds 1 and 2 (each within the scatter of the next).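

In this assay, 2-chlorophenyl in place of 4-(trifluoromethyl)phenyl, on a saturated chain carbon bound to an oxygen on an aromatic ring, gives a 1.2-fold higher number from compound 3 to compound 4 (0.06 log units; within the scatter). Among the compounds shown here, this is the first measured exchange at this position between two ureas, and it changes both the substituent and where it sits on the ring, yet the two compounds remain within the scatter of each other, so this pair shows no sensitivity to the exchange in this assay. Nothing available on these compounds accounts for that result.

Compounds 1 and 2 differ from compounds 3 and 4 in more than one place, so the contribution of the urea link relative to the thiourea link remains unseparated, as do the separate contributions of the substituent and its place on the ring. Also open, from the compounds shown here alone, is whether this tolerance extends to a ring bearing an amine or a carboxylic acid, or to a longer chain between the ether oxygen and the ring.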